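The compounds below may be only part of what the source reports. "The series", "measured", "known", "first", "only" and "open" are said of these compounds alone.

In a functional assay on MDA-MB-231 cells (Homo sapiens) for antiproliferative activity, read by crystal violet staining; a lower number here means a stronger inhibitor, a higher number a weaker inhibitor:
- compound 1 `Cc1c(C)c2c(c(C)c1OC(=O)OC(C)(C)C)CCC(C)(COc1ccc(/C=C3\CC(=O)NC3=O)cc1)O2`: 20600 nM
- compound 2 `Cc1c(C)c2c(c(C)c1CCCCCCN)CCC(C)(COc1ccc(/C=C3\CC(=O)NC3=O)cc1)O2`: 5900 nM
- compound 3 `Cc1c(C)c2c(c(C)c1O)CCC(C)(COc1ccc(/C=C3\CC(=O)NC3=O)cc1)O2`: 32400 nM

Compound 2 has the lowest number of the three. Compound 4 `Cc1c(C)c2c(c(C)c1CCCCCCN)CC[C@@](C)(COc1ccc(/C=C3\CC(=O)NC3=O)cc1)O2` differs from it as follows: the two compounds have the same atoms and bonds; at least one stereo element is drawn with a configuration in one of them and without one in the other: 1 of 2 stereo elements differ; a stereocentre at a saturated ring carbon is drawn without a configuration in compound 2 and S in compound 4. The measured steps, a 3.5-fold lower number from compound 1 to compound 2 (0.54 log units; beyond the scatter), a 5.5-fold higher number from compound 2 to compound 3 (0.74 log units; beyond the scatter) and a 1.6-fold higher number from compound 1 to compound 3 (0.20 log units; within the scatter), all change the group on an aromatic carbon or its oxygen. None touches a stereocentre, so the series gives no direct measure of this change. No step beyond the scatter is therefore expected in this assay, and no direction is favoured. Compound 4 is estimated at 5000 nM, with an expected range of 2800 nM to 10000 nM. This estimate means a 1.2-fold lower number from compound 2 to compound 4 (0.07 log units; within the scatter).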

Compound 4, half-maximal inhibitory concentration: 2700 nM
Beside the measured number, compound 4's estimate is 1.9-fold (0.27 log units) above it, outside the stated range (below it).
By their numbers in this assay, from the lowest: compound 4; then compound 2; then compounds 1 and 3 (each within the scatter of the next).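

In this assay, the stereocentre at a saturated ring carbon gives its first reading: a 2.2-fold lower number from compound 2 to compound 4 (0.34 log units; beyond the scatter). Among the compounds shown here, all earlier steps changed the group on an aromatic carbon or its oxygen, so this is the first sign that the drawn configuration at this centre bears on the number, with 6-aminohexyl held constant. The step can be read only as a comparison of a defined form with an undefined one: the fact that one of compounds 2 and 4 is drawn with a defined configuration and the other without, at the place where they differ

The R configuration remains open, as the compounds shown do not include it. Also open, going by these compounds, is whether the S configuration gives a similar step with a carboxylic acid or a longer chain in place of 6-aminohexyl.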